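Antiproliferative series: from 4-nitrophenyl to pyridin-2-yl

This account rests on a few compounds, and the source may have more. Where it says the series, first, only, none or still open, it means among the compounds named here.

- Compound 1 `O=C(/C=C/c1ccc(O)c(O)c1)N1CCN(c2cccc(Cl)c2)CC1` gives 1.71 ug/mL in a functional assay on B16-F10 cells (Mus musculus) for antiproliferative activity, read by MTT assay, with a stated time of 48 h; a higher number here means a weaker inhibitor, a lower number a stronger inhibitor
- Compound 2 `O=C(/C=C/c1ccc(O)c(O)c1)N1CCN(c2ccc([N+](=O)[O-])cc2)CC1` gives 1.79 ug/mL in this assay

Going by the values given here, compound 2 stands level with compound 1, the only other measured compound, as their two values lie within the scatter of each other. Compound 3 `O=C(/C=C/c1ccc(O)c(O)c1)N1CCN(c2ccccn2)CC1` has not yet been measured. It carries pyridin-2-yl in place of 4-nitrophenyl on an amine nitrogen in a ring, and the difference counts as pyridin-2-yl in place of 4-nitrophenyl on an amine nitrogen in a ring (same place, new group). Among the compounds with values here, one measured step bears on this: a 1.0-fold higher number from compound 1 to compound 2 (0.02 log units; within the scatter), with 4-nitrophenyl replacing 3-chlorophenyl at that place. Within the data shown here, that is thin support, since no measured compound has a ring with a hetero atom there. On that single step, no change beyond the scatter is expected in this assay, in either direction. The expected step is a 1.2-fold higher number from compound 2 to compound 3 (0.09 log units; within the scatter) (an estimate). Compound 3 is estimated at 2.2 ug/mL, with an expected range of 1 ug/mL to 5 ug/mL (estimated limits).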

Compound 3, half-maximal inhibitory concentration: 3.01 ug/mL
Beside the measured number, compound 3's estimate is 1.4-fold (0.14 log units) below it, and the stated range covers the measured number.
By their numbers in this assay, from the lowest: compounds 1, 2 and 3 (each within the scatter of the next).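

Pyridin-2-yl brings the first ring with a hetero atom to this place, and in this assay the change reads as a 1.7-fold higher number from compound 2 to compound 3 (0.23 log units; within the scatter), and, measured against 3-chlorophenyl, as a 1.8-fold higher number from compound 1 to compound 3 (0.25 log units; within the scatter). A six-membered aromatic ring with a hetero atom is therefore accepted on this amine nitrogen, and so far none of the three groups separates from the others. Nothing measured here speaks to the cause of these numbers.

The compounds shown carry only aromatic rings at this place, so how a benzyl group or a short alkyl chain would read on the same nitrogen stays open. Also open, going by these compounds, is whether pyridin-4-yl or pyrimidin-2-yl would read any differently from pyridin-2-yl.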